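Clearance notes: from compound 2 to compound 3

A few compounds are considered here, and "the series" means these few. Any claim that something is new, unique, unknown or untested is made for them only; others in the source may bear on it.

In an in vitro ADME assay on microsomes from liver (Homo sapiens) for pharmacokinetics, read by LC-MS, with a stated time of 10 min, tested at 1 uM (a lower number here means slower removal, a higher number faster removal of the compound), compound 1 (`COc1ccc(NC(=O)[C@H]2CN(C)C[C@@H]2c2ccc(/C=C/C(=O)Nc3ccccc3N)cc2)cc1`) gives 14 mL/min/kg as its number. Among the measured compounds shown here, compound 2 (`CN1C[C@H](C(=O)Nc2ccc(C(F)(F)F)cc2)[C@@H](c2ccc(/C=C/C(=O)Nc3ccccc3N)cc2)C1`) gives 6 mL/min/kg and so holds the lower of the two numbers so far. Compound 3 (`CN1C[C@H](C(=O)Nc2cccc(F)c2)[C@@H](c2ccc(/C=C/C(=O)Nc3ccccc3N)cc2)C1`) carries 3-fluorophenyl in place of 4-(trifluoromethyl)phenyl on an amide-type nitrogen, and the rest of the structure stays the same.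

For the measured compounds named here, one measured step bears on this change. It is a 2.3-fold lower number from compound 1 to compound 2 (0.37 log units; beyond the scatter) and it came with trifluoromethyl in place of methoxy on an aromatic carbon. That step is modest but beyond the scatter. The trifluoromethyl group leaves again in compound 3, so a small rise toward compound 1 at 14 mL/min/kg is expected, though a single step is thin evidence and 3-fluorophenyl was not part of it.

The estimated step is a 1.5-fold higher number from compound 2 to compound 3 (0.18 log units; within the scatter) in this assay and is expected to be upward and within the scatter. For compound 3 the estimated clearance is 9 mL/min/kg with an expected range of 5 mL/min/kg to 16 mL/min/kg for now.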

Compound 3, clearance: 6 mL/min/kg
Compound 3: middle estimate off by 1.5-fold (0.18 log units), on the high side; the measured number falls inside the stated range.
By their numbers in this assay, from the lowest: compounds 2 and 3 (each within the scatter of the next); then compound 1.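

In this assay the exchange of 4-(trifluoromethyl)phenyl for 3-fluorophenyl on the amide-type nitrogen gives no change at the digits printed from compound 2 to compound 3 (within the scatter) and thus separates the two groups by nothing that can be read, so the trifluoromethyl group is not required for compound 3 to reach the clearance of compound 2. Replacing 4-methoxyphenyl with 3-fluorophenyl at the same place gives a 2.3-fold lower number from compound 1 to compound 3 (0.37 log units; beyond the scatter) and matches the printed size of the step to compound 2, which leaves compound 1 alone at the higher number among these three compounds. Nothing available explains why the two fluorine-bearing aryl groups stand level or why compound 1 stands apart.

With only three aryl groups on this nitrogen, the compounds shown do not tell whether the lower clearance belongs to fluorine-bearing groups in general or simply to the absence of methoxy. As far as these compounds go, a phenyl group carrying a nitrile, an unsubstituted phenyl or a pyridine ring at this place would help separate those readings, and changes elsewhere on the shared core remain open.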